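Swapping methyl for methoxy in a weakly cytotoxic sulfone

The source may hold more compounds than are shown below. What is called first, only, known or untested is meant among the compounds shown, and "the series" means these compounds.

Compound 1 `COc1cc(C)cc(S(=O)(=O)c2cccc(N)c2C#N)c1`: 94000 nM
Compound 2 `Cc1cc(C)cc(S(=O)(=O)c2cccc(F)c2C#N)c1`: > 200000 nM

The two compounds were read in a functional assay on MT4 cells (Homo sapiens) for cytotoxicity; a higher number here means a weaker inhibitor, a lower number a stronger inhibitor. Compound 2 stands only at a limit, > 200000 nM, and has no exact number. Compound 3 `COc1cc(C)cc(S(=O)(=O)c2cccc(F)c2C#N)c1` keeps the rest of compound 2 but has methoxy in place of methyl on an aromatic carbon. Among the compounds with values here, no step between measured compounds is available to size this change directly. Within the data shown here, the only guide is compound 1, which also carries methoxy and gives a number, 94000 nM. On that basis, a small move toward a lower number in this assay is expected, perhaps no larger than the scatter. The expected change, an at least 1.1-fold lower number from compound 2 to compound 3 (0.07 log units; that floor lies within the scatter), is therefore modest, and compound 3 may also end at the limit. The estimate for compound 3 is 170000 nM, with an expected range of 70000 nM to 350000 nM.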

Compound 3, half-maximal inhibitory concentration: 8000 nM
The estimate for compound 3 lay 21-fold (1.33 log units) above the measured number, and the stated range ends above it.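

In this assay, methoxy in place of methyl on an aromatic carbon, meta to a large group and meta to a methyl group, gives an at least 25-fold lower number from compound 2 to compound 3 (1.39 log units; beyond the scatter), so this position strongly affects the read-out. Compound 2 stands at a limit and not at a number, so this step gives only a floor for the change: the limit of > 200000 nM in this assay, at which 1 of the 3 values shown sits. With methoxy held in place, fluoro in place of amino on an aromatic carbon gives a 12-fold lower number from compound 1 to compound 3 (1.07 log units; beyond the scatter), so a second place on the shared core also moves the number, and methoxy alone does not fix its level.

The compounds shown leave open whether ethoxy, a hydroxyl group or chlorine at the same place would lower the number as far as methoxy does. They also leave open whether the methoxy step would keep its size with amino in place of fluoro.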